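Furan-2-yl step from compound 3 to compound 4

This account rests on a few compounds, and the source may have more. Where it says the series, first, only, none or still open, it means among the compounds named here.

Compound 1 `COC1=C(C)C(=O)/C(=C(O)/C=C/c2ccc(OC)cc2)C(=O)C1(C)C` gives 2.8 ug/mL
Compound 2 `COC1=C(C)C(=O)/C(=C(O)/C=C/c2ccc(C)cc2)C(=O)C1(C)C` gives "not determined" (no result reported)
Compound 3 `CCc1ccc(/C=C/C(O)=C2/C(=O)C(C)=C(OC)C(C)(C)C2=O)cc1` gives 5.3 ug/mL

All numbers come from a functional assay on 1A9 cells (Homo sapiens) for cytotoxicity (a higher number here means that more compound is needed for the effect, a lower number that less compound is needed), and the series holds only two of them. Going by the values given here, compound 3 gives 5.3 ug/mL and lies within the scatter of compound 1 at 2.8 ug/mL as its only numerical neighbour. Compound 2 offers no comparison.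

The next compound is compound 4 `COC1=C(C)C(=O)/C(=C(O)/C=C/c2ccco2)C(=O)C1(C)C` with furan-2-yl in place of 4-ethylphenyl on a double-bonded chain carbon bound to a double-bonded chain carbon. Among the compounds with values here, no measured step covers this kind of change. The nearest evidence is a 1.9-fold higher number from compound 1 to compound 3 (0.28 log units; within the scatter) and it swaps ethyl in place of methoxy on an aromatic carbon, so it bears on the exchange only indirectly. Within the data shown here, the data hold no measured compound with furan-2-yl, and the direction of any change cannot be read from them. No step beyond the scatter is therefore expected in this assay and the estimated step is a 1.3-fold lower number from compound 3 to compound 4 (0.12 log units; within the scatter) with considerable uncertainty on either side. The estimated value for compound 4 is 4 ug/mL with an expected range of 1.5 ug/mL to 11 ug/mL for the coming measurement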

Compound 4, concentration for half-maximal effect: 7.9 ug/mL
Estimate against measurement, compound 4: 2.0-fold (0.30 log units) below, and the stated range covers the measured number.
By their numbers in this assay, from the lowest: compounds 1, 3 and 4 (each within the scatter of the next, the first and the last beyond it).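

In this assay the place on the double-bonded chain carbon bound to a double-bonded chain carbon now carries a five-membered aromatic ring with a hetero atom, and furan-2-yl in place of 4-ethylphenyl gives a 1.5-fold higher number from compound 3 to compound 4 (0.17 log units; within the scatter), so this exchange does not separate the two compounds. Furan-2-yl in place of 4-methoxyphenyl gives a 2.8-fold higher number from compound 1 to compound 4 (0.45 log units; beyond the scatter), the first step in the series to pass the scatter, although compound 3 remains within the scatter of both compound 1 and compound 4. The data offer no measured explanation for either step.

As far as these compounds go, whether the separation between compound 1 and compound 4 belongs to furan-2-yl itself or to the 4-methoxyphenyl group remains open, as a single pair cannot distinguish the two readings. The behaviour of thiophen-2-yl, of pyridin-3-yl with its ring nitrogen, or of a 4-aminophenyl or 4-carboxyphenyl group at this place also remains unknown, so the compounds shown give no trend across aromatic groups.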